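Swapping 4-Methylphenyl for 2-Methylphenyl: An Open Question

The source may report more compounds than this note shows. Statements on the series, on what has been measured and on what is new or still open speak of the compounds shown alone.

Compound 1 `Cc1ccccc1Nc1nc(C)c(C(=O)/C=C/c2ccc(Cl)cc2)s1` and compound 2 `Cc1ccc(Nc2nc(C)c(C(=O)/C=C/c3ccc(Cl)cc3)s2)cc1` share one core, while compound 3 `COc1cc(/C=C/C(=O)c2sc(Nc3ccc(C)cc3)nc2C)cc(OC)c1OC` carries another; the difference between the two cores is not broken down here. In a functional assay on PC-3 cells (Homo sapiens) for cytotoxicity, read by MTT assay (a lower number here means a stronger inhibitor, a higher number a weaker inhibitor), compound 1 reaches only the limit > 25000 nM, which is a limit of the assay and not a number. Compound 2 likewise stops at the limit > 25000 nM in this assay. Compound 3 also gives only the limit > 25000 nM in this assay. The change from compound 2 to compound 1 is 2-methylphenyl in place of 4-methylphenyl on a nitrogen on an aromatic ring, and a step that the two limits leave unreadable from compound 2 to compound 1 is all those two limits allow. Compound 4 `COc1cc(/C=C/C(=O)c2sc(Nc3ccccc3C)nc2C)cc(OC)c1OC` is the unmeasured partner of compound 3, made by the same change, (2-methylphenyl in place of 4-methylphenyl on a nitrogen on an aromatic ring). Among the compounds with values here, because every value so far sits at the limit of > 25000 nM in this assay, at which 3 of the 3 values shown sit, compound 4 is expected to give about 40000 nM, an expected step that the limit leaves unreadable from compound 3 to compound 4, most likely reported again as a limit.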

Compound 4, half-maximal inhibitory concentration: > 25000 nM
Compound 4: no number, only a limit; the forecaster's own chance of this, stated with the estimate: 85%; the middle value lies beyond the limit too.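

Within the data shown here, compound 3 and compound 4 both end at a limit of the assay, not a number, and no step between them can be read. The compounds shown leave open whether 2-methylphenyl and 4-methylphenyl differ at all in this assay.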